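A few compounds are considered here, and "the series" means these few. Any claim that something is new, unique, unknown or untested is made for them only; others in the source may bear on it.

Measured compounds:
Compound 1, `COc1ccc(NC(=O)c2cc(C#N)ccc2Oc2ccc(OC)cc2)cc1`, gives 2500 nM.
Compound 2, `COc1ccc(Oc2ccc([N+](=O)[O-])cc2C(=O)Nc2ccc(F)cc2)cc1`, gives 7200 nM.
Compound 3, `COc1ccc(NC(=O)c2ccccc2Oc2ccccc2)cc1`, gives "no significant activity" (no number reported).

These three share a core in which an amide links two rings, and they were tested in a functional assay (Homo sapiens) for inhibition, using a membrane potential dye, in the presence of a further agent that is not named here; on this read-out lower numbers stand for stronger inhibition and higher numbers for weaker inhibition. Of the two compounds with a number, compound 2 stands at the higher one, so it is the weaker inhibitor of the pair; compound 1 gives a lower number, and the gap between them is beyond the usual scatter of repeated measurements. Compound 3 gave no number at all in this assay.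

Compound 4, `COc1ccc(Oc2ccc([N+](=O)[O-])cc2C(=O)Nc2ccc(C(C)=O)cc2)cc1`, has not been measured. It differs from compound 2 in one place: acetyl in place of fluoro on an aromatic carbon. The change sits on an aromatic carbon of a six-membered aromatic ring of carbon only, para to a large group, and can be read as 4-fluorophenyl becoming 4-acetylphenyl.

Going by the values given here, no measured pair shows this exact change, so the size and direction of the step in this assay remain open. In the absence of such a pair the estimate stays close to the starting point: compound 4 is expected to give about 7000 nM, within a range from 2500 nM to 20000 nM. The expected step of a 1.0-fold lower number from compound 2 to compound 4 (0.01 log units; within the scatter) is therefore small, and may well fall within the scatter.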

Compound 4, half-maximal inhibitory concentration: 8100 nM
The estimate for compound 4 lay 1.2-fold (0.06 log units) below the measured number; the measured number falls inside the stated range.
By their numbers in this assay, from the lowest: compound 1; then compounds 2 and 4 (each within the scatter of the next).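

Going by these compounds alone, the change from 4-fluorophenyl to 4-acetylphenyl gives the first step that can be read at this position: in this assay, it is a 1.1-fold higher number from compound 2 to compound 4 (0.05 log units; within the scatter). On this read-out, the two compounds cannot be told apart, even though acetyl has more heavy atoms than fluoro and brings a hydrogen-bond acceptor that fluoro does not. So at this position, in this one pair, replacing a single fluoro atom with a larger group leaves the inhibition within the scatter, and nothing measured here bears on why the number holds steady.

As far as these compounds go, it remains open whether other groups at the same position, such as an amine, a carboxylic acid or a longer chain, would also leave the number in place or would shift it in either direction. From the compounds shown here alone, it is also open whether acetyl would give a similar result on the core of compound 1, which has a nitrile and gives the lowest number so far, since a single step on one core cannot show how far this result carries over.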